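The source may report more compounds than this note shows. Statements on the series, on what has been measured and on what is new or still open speak of the compounds shown alone.

In an ADME assay on the whole organism with Oryza sativa as the target, tested at 10 uM (on this read-out lower numbers stand for a stronger effect and higher numbers for a weaker effect at the one concentration tested), compound 1, `CC(C)c1ccc(NC(=O)N[C@H](C)c2ccccc2)cc1`, gives 49%, the lowest of the three numbers measured. Compound 2, `CC(C)c1ccc(NC(=O)N[C@@H](C)c2ccccc2)cc1`, gives 86%, and compound 3, `CC(=O)c1ccccc1NC(=O)N[C@@H](C)c1ccccc1`, gives 96%. For the measured compounds named here, the one step between compounds that differ in a single place is a number 37 percentage points higher from compound 1 to compound 2 (beyond the scatter), which rests on the fact that compounds 1 and 2 differ only in the configuration as drawn and says nothing about the groups on the ring. Compound 4, `C[C@@H](NC(=O)Nc1ccc(F)cc1)c1ccccc1`, differs from compound 1 by fluoro in place of isopropyl on an aromatic carbon. Going by the values given here, no measured step covers this exchange, so the direction is open. The expectation for compound 4 in this assay is 65%, within 40% to 90%, which would mean an estimated a number 16 percentage points higher from compound 1 to compound 4 (beyond the scatter).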

Compound 4, a percentage reported as activity, at one concentration (the size of the read-out at that concentration, not a potency): 92%
Compound 4: the middle estimate sits 27 percentage points below what was measured; measured number outside the range, above it.
By their numbers in this assay, from the lowest: compound 1; then compounds 2, 4 and 3 (each within the scatter of the next).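

For the compounds shown here, until now the only step rested on the stereocentre: the fact that compounds 1 and 2 differ only in the configuration as drawn. In this assay, the ring group now matters too, since fluoro in place of isopropyl, on an aromatic carbon para to a large group, gives a number 43 percentage points higher from compound 1 to compound 4 (beyond the scatter). The low number of compound 1 therefore needs more than its configuration, and a change at this ring carbon also takes it away.

Why this exchange has so large an effect cannot be told from these compounds. On these data alone, it also remains open whether an ethyl, a tert-butyl or an amine at this place would keep the number as low as in compound 1.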